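The source may hold more compounds than are shown below. What is called first, only, known or untested is meant among the compounds shown, and "the series" means these compounds.

Compound 1, `Cc1cnc(Nc2ccc(S(C)(=O)=O)cc2)nc1Nc1nc2ccc(Cl)cc2s1`, gives 4320 nM in a functional assay on MCF7 cells (Homo sapiens) for antiproliferative activity, read by MTT assay, with a stated time of 48 h; on this read-out higher numbers stand for weaker inhibition and lower numbers for stronger inhibition. Compound 2, `Cc1ccc2nc(Nc3nc(Nc4ccc(S(N)(=O)=O)cc4)ncc3C)sc2c1`, gives > 50000 nM in this assay, a limit. Compound 3, `Cc1cnc(Nc2ccc(S(N)(=O)=O)cc2)nc1Nc1nc2ccccc2s1`, gives > 50000 nM in this assay, a limit.

Compound 3 therefore stands at the limit of this assay, without a number; (the limit of > 50000 nM in this assay, at which 2 of the 3 values shown sit). Compound 4, `Cc1cnc(Nc2ccc(S(N)(=O)=O)cc2)nc1Nc1nc2ccc(Cl)cc2s1`, differs from compound 3 by chloro in place of hydrogen on an aromatic carbon. Among the measured compounds shown here, the only measured step, a step that the two limits leave unreadable from compound 2 to compound 3, concerns a methyl, not this chloro, and is unreadable. For the measured compounds named here, compound 1 carries the same chloro and gives 4320 nM in this assay, but it also differs from compound 4 at the sulfonyl group, and no step is given for that pair. The expected step from compound 3 to compound 4 is an at least 2.0-fold lower number from compound 3 to compound 4 (0.30 log units; that floor lies within the scatter) toward stronger inhibition, with wide uncertainty. Compound 4 is estimated at 25000 nM, between 6000 nM and 100000 nM.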

Compound 4, half-maximal inhibitory concentration: 8430 nM
Compound 4: the middle estimate sits 3.0-fold (0.47 log units) above what was measured; the measured number falls inside the stated range.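

Chloro on this aromatic carbon turns a limit into a readable value in this assay, with an at least 5.9-fold lower number from compound 3 to compound 4 (0.77 log units; beyond the scatter), and chloro in place of methyl gives an at least 5.9-fold lower number from compound 2 to compound 4 (0.77 log units; beyond the scatter). Among the compounds shown here, with the chloro present, the sulfonyl end can be read for the first time, and amino in place of methyl on the sulfonyl sulfur gives a 2.0-fold higher number from compound 1 to compound 4 (0.29 log units; within the scatter), so no difference can be claimed there. Compound 2 and compound 3 each stand at a limit, so both chloro steps are floors and not sizes: the limit of > 50000 nM in this assay, at which 2 of the 4 values shown sit.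

Going by these compounds, the true size of those chloro steps stays open. So does what fluoro, bromo or a methoxy group would give on this carbon.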